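Methyl to tert-butyl: the step to compound 4

The source may hold more compounds than are shown below. What is called first, only, known or untested is meant among the compounds shown, and "the series" means these compounds.

Measured in a functional assay on HT-29 cells (Homo sapiens) for antiproliferative activity, read by MTT assay, with a stated time of 96 h; a higher number here means a weaker inhibitor, a lower number a stronger inhibitor
- compound 1 `O=C1C2=C(C(=O)c3ncccc31)C1(CS2)NC(=O)N(c2ccc(Cl)cc2)C1=O` gives 2 nM
- compound 2 `O=C1C2=C(C(=O)c3ncccc31)C1(CS2)NC(=O)N(c2ccc([N+](=O)[O-])cc2)C1=O` gives 250 nM
- compound 3 `Cc1ccc(N2C(=O)NC3(CSC4=C3C(=O)c3ncccc3C4=O)C2=O)cc1` gives 1 nM

Compound 3 stands level with compound 1 at the low end of these numbers, the gap being a 2.0-fold lower number from compound 1 to compound 3 (0.30 log units; within the scatter), and far from compound 2, with a 250-fold lower number from compound 2 to compound 3 (2.40 log units; beyond the scatter) between them. The next compound is compound 4 `CC(C)(C)c1ccc(N2C(=O)NC3(CSC4=C3C(=O)c3ncccc3C4=O)C2=O)cc1`, which has tert-butyl in place of methyl on an aromatic carbon, para to a large group: tert-butyl in place of methyl on an aromatic carbon. Only changes at this same place bear on it. Swapping chloro for methyl left the number within the scatter, whereas swapping chloro for nitro gave a 130-fold higher number from compound 1 to compound 2 (2.10 log units; beyond the scatter), so this place can respond strongly or hardly at all. For the measured compounds named here, no measured compound carries tert-butyl, so a modest rise in this assay is expected, with a wide margin on the weaker side. The expected step is a 4.0-fold higher number from compound 3 to compound 4 (0.60 log units; beyond the scatter) by this estimate. The estimate for compound 4 is 4 nM, with an expected range from 0.8 nM to 30 nM in this estimate.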

Compound 4, half-maximal inhibitory concentration: 150 nM
For compound 4 the middle estimate is 38-fold (1.57 log units) below the measured one; measured number outside the range, above it.
By their numbers in this assay, from the lowest: compounds 3 and 1 (each within the scatter of the next); then compounds 4 and 2 (each within the scatter of the next).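

In this assay, enlarging the methyl to tert-butyl, from one carbon to four, gives a 150-fold higher number from compound 3 to compound 4 (2.18 log units; beyond the scatter), so a large loss at this place is no longer tied to nitro and also follows from a change that involves only carbon. Measured against the chloro group the picture is the same, with a 75-fold higher number from compound 1 to compound 4 (1.88 log units; beyond the scatter), while the tert-butyl and nitro groups stand level, with a 1.7-fold lower number from compound 2 to compound 4 (0.22 log units; within the scatter), although they have nothing in common but their place on the ring. Nothing available explains why these two groups end up level or why methyl and chloro keep the number low.

The compounds shown leave open where along the way from methyl to tert-butyl the loss sets in, which ethyl or isopropyl at this place would show. They also leave open whether an amine or a methoxy group here would stay with methyl and chloro or fall with nitro and tert-butyl.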